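From an Ester Back to an Amide: Compound 4

A few compounds are considered here, and "the series" means these few. Any claim that something is new, unique, unknown or untested is made for them only; others in the source may bear on it.

Compound 1 `CC(C)NC(=O)/C=C/c1ccccc1` — 39%
Compound 2 `C=CCNC(=O)/C=C/c1ccccc1` — 63%
Compound 3 `CC(C)OC(=O)/C=C/c1ccccc1` — 2%

In a functional assay on the whole organism for inhibition, with Brassica rapa subsp. chinensis as the target, with a stated time of 3 days, tested at 100 ppm (a lower number here means less inhibition of growth, a higher number more inhibition of growth at the concentration tested), compound 3 gives 2%, the lowest of the three numbers. The two amides stand well above it: the shift was a number 37 percentage points lower from compound 1 to compound 3 (beyond the scatter) and a number 61 percentage points lower from compound 2 to compound 3 (beyond the scatter). Compound 4 `CC(C)CNC(=O)/C=C/c1ccccc1` differs from compound 3 by isobutylamino in place of isopropoxy on a carbonyl carbon. Both measured steps that set isopropoxy in place of an amino group on the carbonyl carbon were large drops, so the reverse exchange is expected to raise the number substantially. For compound 4 the estimated step is a number 43 percentage points higher from compound 3 to compound 4 (beyond the scatter). Compound 4 is therefore expected to give 45%, with a range of 22% to 68%.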

Compound 4, percent growth inhibition at one concentration: 34%
Compound 4: the middle estimate sits 11 percentage points above what was measured; the measured number falls inside the stated range.
By their numbers in this assay, from the lowest: compound 3; then compounds 4 and 1 (each within the scatter of the next); then compound 2.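

In this assay, the gain on going from ester to amide also appears with a third amino group, isobutylamino in place of isopropoxy on the carbonyl carbon: a number 32 percentage points higher from compound 3 to compound 4 (beyond the scatter). On the amide-type nitrogen, isobutyl in place of isopropyl leaves the two saturated groups unresolved, a number 5 percentage points lower from compound 1 to compound 4 (within the scatter), while the unsaturated allyl of compound 2 stands apart from isobutyl, a number 29 percentage points lower from compound 2 to compound 4 (beyond the scatter). Nothing measured here gives a reason for these steps. The compounds shown leave open how a propargyl group or a longer chain on that nitrogen would read. They also leave open whether an unsubstituted amide or a carboxylic acid would follow the amides or the ester.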